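The compounds below may be only part of what the source reports. "The series", "measured", "known", "first", "only" and "open" are said of these compounds alone.

Two members of the shared core are measured in an ADME assay on cells for inhibition of Intestinal-type alkaline phosphatase (Homo sapiens), read by luminescence, with stated times of 7 min and 20 min; on this read-out higher numbers stand for weaker inhibition and lower numbers for stronger inhibition: compound 1 `CCCCNc1nn2c(=O)cc(C(F)(F)F)nc2s1` gives 710 nM, and compound 2 `CN(N)c1nn2c(=O)cc(C(F)(F)F)nc2s1` gives 2220 nM, the highest of the two numbers. Within the data shown here, the only measured step, a 3.1-fold higher number from compound 1 to compound 2 (0.50 log units; beyond the scatter), exchanges one amine for another. Compound 3 `O=c1cc(C(F)(F)F)nc2sc(-c3ccccc3F)nn12` differs from compound 2 by 2-fluorophenyl in place of amino(methyl)amino on an aromatic carbon. Among the measured compounds shown here, no measured step replaces an amine with an aryl ring, so the step from compound 1 to compound 2 bears only loosely here. The expected step is a 1.5-fold lower number from compound 2 to compound 3 (0.17 log units; within the scatter), without a clear direction beyond the scatter. Compound 3 is estimated at 1500 nM, within 300 nM to 8000 nM.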

Compound 3, half-maximal inhibitory concentration: > 100000 nM
Compound 3: only a limit was reported; the forecaster's own chance of this, stated with the estimate: 10%; middle value at least 66-fold (1.82 log units) away from the limit.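

Replacing an amine on this aromatic carbon, next to the ring nitrogen and the ring sulfur, with 2-fluorophenyl matters far more in this assay than exchanging one amine for another: an at least 45-fold higher number from compound 2 to compound 3 (1.65 log units; beyond the scatter) and an at least 140-fold higher number from compound 1 to compound 3 (2.14 log units; beyond the scatter) stand against a 3.1-fold higher number from compound 1 to compound 2 (0.50 log units; beyond the scatter). Among the compounds shown, only the two with an amine at this position give a number. For compound 3 the reading is a limit and not a number: the limit of > 100000 nM in this assay, at which 1 of the 3 values shown sits.

Going by these compounds, whether the loss follows from the missing amine, the aryl ring or its fluorine stays open. An unsubstituted phenyl or an anilino group at this position would separate these.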